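The source may hold more compounds than are shown below. What is called first, only, known or untested is meant among the compounds shown, and "the series" means these compounds.

In a functional assay on K562 cells (Homo sapiens) for antiproliferative activity, read by MTT assay, with a stated time of 72 h (on this read-out lower numbers stand for stronger inhibition and higher numbers for weaker inhibition), compound 1 `COc1cc(C(=O)c2sc3ccccc3c2-c2ccc(Cl)cc2)cc(OC)c1OC` gives 4200 nM and compound 2 `COc1ccc(-c2c(C(=O)c3cc(OC)c(OC)c(OC)c3)sc3ccccc23)cc1` gives 1700 nM, the lower of the two numbers. Compound 3 `COc1cc(C(=O)c2sc3ccccc3c2-c2ccc(SC)cc2)cc(OC)c1OC` keeps the rest of compound 2 but carries methylsulfanyl in place of methoxy on an aromatic carbon. Among the measured compounds shown here, the only measured step on this same carbon, a 2.5-fold lower number from compound 1 to compound 2 (0.39 log units; beyond the scatter), replaced chloro with methoxy and was modest, so only a small change is expected here, with no firm direction. The expected change is a 1.3-fold higher number from compound 2 to compound 3 (0.11 log units; within the scatter), which would not stand beyond the scatter. For compound 3 the estimated value is 2200 nM, with an expected range of 900 nM to 5000 nM.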

Compound 3, half-maximal inhibitory concentration: 1800 nM
The estimate for compound 3 lay 1.2-fold (0.09 log units) above the measured number; the range from low to high includes it.
By their numbers in this assay, from the lowest: compounds 2 and 3 (each within the scatter of the next); then compound 1.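

Swapping methoxy for methylsulfanyl in this assay gives a 1.1-fold higher number from compound 2 to compound 3 (0.02 log units; within the scatter) and so leaves the two compounds indistinguishable on this aromatic carbon. Methylsulfanyl in place of chloro gives a 2.3-fold lower number from compound 1 to compound 3 (0.37 log units; beyond the scatter) and shows that a second group, not only methoxy, stands beyond the scatter from chloro here. No measurement is available that explains why methoxy and methylsulfanyl read alike.

From the compounds shown here alone, whether an amine, a carboxylic acid or a longer chain such as butoxy on this carbon would shift the number further remains open. Also open, going by these compounds, is whether the same swap would read alike elsewhere on the shared core.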